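Swapping the imidazole for a carbamoyl pyrazole

A few compounds are considered here, and "the series" means these few. Any claim that something is new, unique, unknown or untested is made for them only; others in the source may bear on it.

Measured in an ADME assay on microsomes from liver (Homo sapiens) for metabolic stability, read by LC-MS, using NADPH, with stated times of 5 min and 30 min, tested at 1 uM; a higher number here means faster removal of the compound, a lower number slower removal:
Compound 1 `Cn1nccc1-c1cnc(NCc2c(F)ccc3c2CCO3)c2cn[nH]c(=O)c12`: 14 mL.min-1.g-1
Compound 2 `Cc1ncc(-c2cnc(NCc3c(F)ccc4c3CCO4)c3cn[nH]c(=O)c23)n1C`: 10 mL.min-1.g-1

Compound 2, at 10 mL.min-1.g-1, lies within the scatter of compound 1, so the two cannot be ranked. Compound 3 `CN(C)C(=O)c1cc(-c2cnc(NCc3c(F)ccc4c3CCO4)c3cn[nH]c(=O)c23)n(C)n1` has 3-(dimethylcarbamoyl)-1-methyl-1H-pyrazol-5-yl in place of 1,2-dimethyl-1H-imidazol-5-yl on an aromatic carbon. Among the compounds with values here, the one measured step bearing on this change is a 1.4-fold lower number from compound 1 to compound 2 (0.15 log units; within the scatter), which exchanged a 1-methyl-1H-pyrazol-5-yl for the same imidazole. Nothing measured tests the dimethylcarbamoyl group, so no shift beyond the scatter is expected in this assay. The expected change is a 1.2-fold higher number from compound 2 to compound 3 (0.08 log units; within the scatter). For compound 3 the estimate is 12 mL.min-1.g-1, with an expected range of 6 mL.min-1.g-1 to 24 mL.min-1.g-1.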

Compound 3, intrinsic clearance in microsomes in the Homo sapiens assay: 21 mL.min-1.g-1
For compound 3 the middle estimate is 1.8-fold (0.24 log units) below the measured one, and the stated range covers the measured number.
By their numbers in the Homo sapiens assay, from the lowest: compounds 2, 1 and 3 (each within the scatter of the next, the first and the last beyond it).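

In the Homo sapiens assay, replacing the imidazole with the carbamoyl pyrazole at this position gives a 2.1-fold higher number from compound 2 to compound 3 (0.32 log units; beyond the scatter), whereas adding dimethylcarbamoyl to the simple pyrazole gives a 1.5-fold higher number from compound 1 to compound 3 (0.18 log units; within the scatter). Only the first of these steps clears the scatter, so the dimethylcarbamoyl group alone has no readable effect on this number. In a physicochemical assay for solubility, read by LC-MS, in phosphate buffer, with a stated time of 24 h, at pH 7.4 (a higher number here means a more soluble compound, a lower number a less soluble compound), compound 2 gives 15000 nM and compound 3 gives 3000 nM. The exchange also carries a cost in the physicochemical assay: the measured solubility of compound 2, 15000 nM, and of compound 3, 3000 nM, a 5.0-fold lower number (0.70 log units; beyond the scatter)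

The compounds shown leave open whether a primary carboxamide or an aminomethyl group on the pyrazole would give a number in the Homo sapiens assay closer to that of compound 2, and how either would read in the physicochemical assay.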